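Piperidinyl in place of cyclohexenyl on the shared core

The source may report more compounds than this note shows. Statements on the series, on what has been measured and on what is new or still open speak of the compounds shown alone.

Compound 1 `O=C(O)c1csc(-n2nc(-c3cccc(F)c3)c3ccccc32)n1`: 20 nM
Compound 2 `O=C(O)c1csc(-n2nc(C3=CCCCC3)c3ccccc32)n1`: 4 nM

In an assay on isolated protein for antagonist activity at prostaglandin E2 receptor EP1 subtype (Homo sapiens), read by reporter gene assay (on this read-out higher numbers stand for weaker inhibition and lower numbers for stronger inhibition), compound 2 gives the lowest of the two numbers; its nearest neighbour, compound 1, sits at 20 nM, a gap of a 5.0-fold lower number from compound 1 to compound 2 (0.70 log units; beyond the scatter). Compound 3 `O=C(O)c1csc(-n2nc(N3CCCCC3)c3ccccc32)n1` carries the change (piperidin-1-yl in place of cyclohex-1-en-1-yl on an aromatic carbon). For the measured compounds named here, the single measured step, a 5.0-fold lower number from compound 1 to compound 2 (0.70 log units; beyond the scatter), concerns a different exchange at the same aromatic carbon and so bears on this one only loosely; it shows that a non-aromatic ring is accepted there. For compound 3 a step of a 2.5-fold higher number from compound 2 to compound 3 (0.40 log units; beyond the scatter) is therefore expected, toward a weaker number, with wide uncertainty. Compound 3 is estimated at 10 nM, between 2 nM and 50 nM.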

Compound 3, half-maximal inhibitory concentration: 16 nM
Estimate against measurement, compound 3: 1.6-fold (0.20 log units) below, within the range that was stated.
By their numbers in this assay, from the lowest: compound 2; then compounds 3 and 1 (each within the scatter of the next).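

In this assay, piperidin-1-yl on this aromatic carbon does not hold the number reached with cyclohex-1-en-1-yl (a 4.0-fold higher number from compound 2 to compound 3 (0.60 log units; beyond the scatter)). Against 3-fluorophenyl, it shows no difference that can be separated from the scatter (a 1.3-fold lower number from compound 1 to compound 3 (0.10 log units; within the scatter)). A six-membered non-aromatic ring with a nitrogen is therefore accepted here, but it does not match the all-carbon ring with its double bond. Nothing available explains this step. The compounds shown leave open whether a saturated cyclohexyl ring would behave like cyclohex-1-en-1-yl or like piperidin-1-yl. They also leave open how a morpholine ring would fare at this position.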